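Swapping cyano for pyrrolidin-1-yl on an imidazolium oxime

This account rests on a few compounds, and the source may have more. Where it says the series, first, only, none or still open, it means among the compounds named here.

This account follows three measured or attempted imidazolium oximes and one compound still awaiting measurement. Compound 1 `C[n+]1ccn(COCCC[Si](C)(C)C)c1/C=N/O` carries a trimethylsilyl-bearing ether chain; in a physicochemical assay for lipophilicity (on this read-out higher numbers stand for higher lipophilicity and lower numbers for lower lipophilicity), compound 1 gives 0.43. Compound 2 `C[n+]1ccn(CCC#N)c1/C=N/O` carries a short chain ending in a nitrile; in this assay compound 2 gives -3.3, the lowest of the two numbers available, and its gap to compound 1 lies well beyond the scatter. Compound 3 `C[n+]1ccn(COCC[N+](=O)[O-])c1/C=N/O` in this assay gives no result reported. No pair of these compounds differs in only one place, so no single-point step can be read from the measured set.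

The unmeasured compound 4 `C[n+]1ccn(CCN2CCCC2)c1/C=N/O` differs from compound 2 in one place: pyrrolidin-1-yl in place of cyano on a saturated chain carbon, two bonds along the chain from an aromatic nitrogen. Among the measured compounds shown here, the only comparison available, compound 1 at 0.43 against compound 2 at -3.3, involves chains that differ in several places at once and cannot be carried over to this change.

For compound 4 in this assay the step from compound 2 is expected to be small, a number 0.20 log units lower from compound 2 to compound 4 (within the scatter), close to the scatter and leaning, if anything, downward. Compound 4 is therefore estimated at -3.5, within a range from -4.5 to -2.5.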

Compound 4, distribution coefficient: -2.73
Compound 4: the middle estimate sits 0.77 log units below what was measured; measured number inside the range.
By their numbers in this assay, from the lowest: compound 2; then compound 4; then compound 1.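

In this assay, the exchange of cyano for pyrrolidin-1-yl on a saturated chain carbon, two bonds along the chain from an aromatic nitrogen, now gives the series its first step that can be read at a single place: a number 0.57 log units higher from compound 2 to compound 4 (beyond the scatter). The step is modest, yet it lies beyond the usual scatter, so at this position the two groups can be told apart on this read-out, even though the group that leaves has 2 heavy atoms and no ring, while the group that enters has 5 heavy atoms and one five-membered non-aromatic ring, and each counts 1 hydrogen-bond acceptor. Nothing among the data shown accounts for the direction or the size of this step, which therefore stands as an observation without an explanation.

With a single pair behind it, the step says nothing yet about whether the same exchange would behave alike on a longer chain. It also leaves open where groups such as piperidin-1-yl, morpholin-4-yl or an open-chain dimethylamino group would fall at this same place on the shared core.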